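This account rests on a few compounds, and the source may have more. Where it says the series, first, only, none or still open, it means among the compounds named here.

Values measured so far in a functional assay on HepG2 cells (Homo sapiens) for inhibition, read by MTT assay; on this read-out lower numbers stand for stronger inhibition and higher numbers for weaker inhibition:
- compound 1 `COc1cc2ncnc(Nc3ccc(NC(=O)c4cccc(F)c4)cc3)c2cc1OC` (8200 nM)
- compound 2 `COc1cc2ncnc(Nc3ccc(NC(=O)c4cccc(I)c4)cc3)c2cc1OC` (28000 nM)
- compound 3 `COc1cc2ncnc(Nc3ccc(NC(=O)c4cccc(C(F)(F)F)c4)cc3)c2cc1OC` (83000 nM)

Compound 3 gives the highest number of the three. The smaller gap to it is a 3.0-fold higher number from compound 2 to compound 3 (0.47 log units; beyond the scatter) and the larger is a 10-fold higher number from compound 1 to compound 3 (1.01 log units; beyond the scatter), and the remaining step is a 3.4-fold higher number from compound 1 to compound 2 (0.53 log units; beyond the scatter).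

Compound 4 `COc1cc2ncnc(Nc3ccc(NC(=O)c4ccc(Cl)c(Cl)c4)cc3)c2cc1OC` carries 3,4-dichlorophenyl in place of 3-(trifluoromethyl)phenyl on a carbonyl carbon. All three measured steps bear on this change only indirectly, as each exchanges one group on an aromatic carbon, and they range from modest to large. Within the data shown here, no measured compound carries chlorine, so no step speaks to the new group directly. Compound 1 and compound 2 both lack trifluoromethyl and both stand lower than compound 3, and the nearer of them gives a 3.0-fold higher number from compound 2 to compound 3 (0.47 log units; beyond the scatter) as the guide. A modest step to a lower number is therefore expected in this assay, with a wide margin. The expected step is a 2.8-fold lower number from compound 3 to compound 4 (0.44 log units; beyond the scatter). For compound 4 the estimated value is 30000 nM, with an expected range from 9000 nM to 90000 nM.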

Compound 4, half-maximal inhibitory concentration: 28000 nM
Beside the measured number, compound 4's estimate is 1.1-fold (0.03 log units) above it; the range from low to high includes it.
By their numbers in this assay, from the lowest: compound 1; then compounds 2 and 4 (each within the scatter of the next); then compound 3.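

In this assay, 3,4-dichlorophenyl in place of 3-(trifluoromethyl)phenyl on the carbonyl carbon gives a step to a lower number (a 3.0-fold lower number from compound 3 to compound 4 (0.47 log units; beyond the scatter)), so this position tolerates chlorine on the ring and a group with two substituents does not by itself give the highest number in the set. Against 3-iodophenyl the same group gives (no change at the digits printed from compound 2 to compound 4 (within the scatter)), and against 3-fluorophenyl it gives (a 3.4-fold higher number from compound 1 to compound 4 (0.53 log units; beyond the scatter)), so compound 1 keeps the lowest number of the four and 3,4-dichlorophenyl does not reach the level of 3-fluorophenyl. The compounds shown offer no measurement that could explain this order.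

Still open is how much each chlorine contributes, since neither 3-chlorophenyl nor 4-chlorophenyl stands among these compounds, so the dichloro result cannot be divided between its two substituents. Also open is whether a methoxy group, an amine or a carboxylic acid on this phenyl ring would give a number lower than that of compound 1 (8200 nM), as every group shown here carries only halogen or trifluoromethyl.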